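Compound 3: one ring swapped on an amide-type nitrogen

The source may hold more compounds than are shown below. What is called first, only, known or untested is meant among the compounds shown, and "the series" means these compounds.

Compound 1 `O=C(Nc1cccc(Cl)c1)Nc1cc2ncncc2cc1OCc1ccccc1Cl`: > 10000 nM, a limit
Compound 2 `O=C(Nc1cccc(Cl)c1)Nc1cc2ncncc2cc1OCc1cccc(Cl)c1`: > 10000 nM, a limit

In an ADME assay on cells (Astrocyte, Homo sapiens) for cytotoxicity, read by WST assay, with a stated time of 72 h (a lower number here means a stronger inhibitor, a higher number a weaker inhibitor), compound 2 gives > 10000 nM, which is a limit and not a number. The whole picture so far is the limit of > 10000 nM in this assay, at which 2 of the 2 values shown sit. Compound 2 therefore has no exact place on the scale.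

Compound 3 `O=C(Nc1ccccc1F)Nc1cc2ncncc2cc1OCc1cccc(Cl)c1` keeps the shared core but carries 2-fluorophenyl in place of 3-chlorophenyl on an amide-type nitrogen. Among the measured compounds shown here, the only measured step is a step that the two limits leave unreadable from compound 1 to compound 2. It lies elsewhere in the molecule and offers no size to carry over. No change beyond the usual scatter is therefore expected in this assay, and no direction can be named. The expected change is a step that the limit leaves unreadable from compound 2 to compound 3. The estimated value for compound 3 is 15000 nM, with an expected range of 7000 nM to 30000 nM.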

Compound 3, half-maximal inhibitory concentration: 8700 nM
For compound 3 the middle estimate is 1.7-fold (0.24 log units) above the measured one, and the stated range covers the measured number.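

In this assay, compound 3 gives 8700 nM, the only exact number shown, so this swap on the amide-type nitrogen puts a compound on the scale for the first time. Compound 2 gives > 10000 nM, which is a limit and not a number. The change can therefore be told only as an at least 1.1-fold lower number from compound 2 to compound 3 (0.06 log units; that floor lies within the scatter), so the true gap may be larger or may lie within the scatter, while the earlier step, which joins two limits, cannot be read.

Most of the picture still rests on one limit: the limit of > 10000 nM in this assay, at which 2 of the 3 values shown sit. The swap also changes both the halogen and the name's ring position at once, so 3-fluorophenyl or plain phenyl on the same nitrogen would be needed to tell those two changes apart.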